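The compounds below may be only part of what the source reports. "The series", "measured", "known", "first", "only" and "open" are said of these compounds alone.

Measured so far:
- compound 1 `COc1ccc([C@@H]2Oc3ccc(/C=C/C=O)cc3O[C@H]2CO)cc1OC` gives 4000 nM in a functional assay on HCT-116 cells (Homo sapiens) for antiproliferative activity, read by sulforhodamine B assay, with a stated time of 72 h; a higher number here means a weaker inhibitor, a lower number a stronger inhibitor
- compound 2 `COc1ccc([C@@H]2Oc3ccc(/C=C/C=O)cc3O[C@H]2COC(C)=O)cc1OC` gives 5600 nM in this assay

For the measured compounds named here, compound 1 holds the lowest of the two numbers in this assay, though the single measured step, a 1.4-fold higher number from compound 1 to compound 2 (0.15 log units; within the scatter), lies within the scatter. Compound 3 `COc1ccc([C@@H]2Oc3ccc(C=O)cc3O[C@H]2CO)cc1OC` differs from compound 1 by formyl in place of 2-formylethenyl on an aromatic carbon. Going by the values given here, no measured step bears on this change: the only one known concerns acetyl in place of hydrogen on an oxygen on a saturated carbon, a different position. The expectation for compound 3 is therefore a somewhat higher number, a 3.8-fold higher number from compound 1 to compound 3 (0.57 log units; beyond the scatter), in this assay, with wide uncertainty. The estimate for compound 3 is 15000 nM, expected between 4000 nM and 60000 nM.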

Compound 3, half-maximal inhibitory concentration: > 100000 nM
Compound 3 ended at the assay's limit (the forecaster's own chance of this, stated with the estimate: 25%); at least 6.6-fold (0.82 log units) between middle value and limit.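

At this aromatic carbon the series responds strongly: formyl in place of 2-formylethenyl gives an at least 25-fold higher number from compound 1 to compound 3 (1.39 log units; beyond the scatter) in this assay, whereas the acetyl change on the oxygen gave only a 1.4-fold higher number from compound 1 to compound 2 (0.15 log units; within the scatter). The value of compound 3 is a limit of the assay, not a number: the limit of > 100000 nM in this assay, at which 1 of the 3 values shown sits.

The compounds shown do not separate the loss of the carbon-carbon double bond from the shortening of the chain. On these data alone, how a saturated 3-oxopropyl group, a carboxylic acid or an amine would read at this aromatic carbon stays open.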